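Compound 2 to compound 3: ethyl gives way to methoxycarbonyl

A few compounds are considered here, and "the series" means these few. Any claim that something is new, unique, unknown or untested is made for them only; others in the source may bear on it.

Compound 1 `CCCCCCCCCCCCCCCCC(=O)c1csc(-c2ccccc2)n1`: > 20000 nM (a limit)
Compound 2 `CCc1ccc(-c2nc(C(=O)c3cc(OC)c(OC)c(OC)c3)cs2)cc1`: 60 nM

Going by the values given here, in a functional assay on LNCaP cells (Homo sapiens) for cytotoxicity, read by sulforhodamine B assay, with a stated time of 48 h (on this read-out lower numbers stand for stronger inhibition and higher numbers for weaker inhibition), compound 2 gives 60 nM, the only actual number so far. Compound 1 gives > 20000 nM, which is a limit of the assay and not a number.

Compound 3 `COC(=O)c1ccc(-c2nc(C(=O)c3cc(OC)c(OC)c(OC)c3)cs2)cc1` differs from compound 2 in one place: methoxycarbonyl in place of ethyl on an aromatic carbon. Methoxycarbonyl stands in place of ethyl on an aromatic carbon, para to a large group. Among the compounds with values here, no measured pair shows what such a change does in this assay. A modest loss of potency, somewhat beyond the scatter, is therefore only an expectation, starting from compound 2 at 60 nM. The expected change is a 2.5-fold higher number from compound 2 to compound 3 (0.40 log units; beyond the scatter). For compound 3 the estimated half-maximal inhibitory concentration is 150 nM, with an expected range of 40 nM to 800 nM.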

Compound 3, half-maximal inhibitory concentration: > 20000 nM
Compound 3: a limit, no number (the forecaster's own chance of this, stated with the estimate: 3%); at least 130-fold (2.12 log units) between middle value and limit.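

The position on the aromatic carbon, para to a large group, turns out not to be indifferent: with the rest of the molecule unchanged, methoxycarbonyl in place of ethyl gives an at least 330-fold higher number from compound 2 to compound 3 (2.52 log units; beyond the scatter) in this assay. In this assay compound 3 gives > 20000 nM, which is a limit of the assay and not a number. The step therefore marks only the least that this one change costs, and its true size is cut off by the limit: the limit of > 20000 nM in this assay, at which 2 of the 3 values shown sit.

From the compounds shown here alone, how far compound 3 lies past that limit stays open. So does whether a methyl group, a methoxy group, a carboxylic acid, an amine or a longer chain on this same carbon would stay close to compound 2 or fall away as methoxycarbonyl does.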